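The source may report more compounds than this note shows. Statements on the series, on what has been measured and on what is new or still open speak of the compounds shown alone.

Measured compounds:
- compound 1, `ClCc1ccc(Cn2cnc3c(Cl)ncnc32)cc1`: 9450 nM
- compound 2, `Nc1nc(Cl)c2ncn(Cc3ccc(CCl)cc3)c2n1`: 53700 nM
- compound 3, `ClCc1ccccc1Cn1cnc2c(Cl)ncnc21`: 28200 nM

The three measured compounds were tested in a functional assay on UACC-62 cells (Homo sapiens) for cytotoxicity, read by sulforhodamine B assay, with a stated time of 48 h; on this read-out higher numbers stand for lower toxicity in this test and lower numbers for higher toxicity in this test. Compound 1, `ClCc1ccc(Cn2cnc3c(Cl)ncnc32)cc1`, gives 9450 nM. Compound 2, `Nc1nc(Cl)c2ncn(Cc3ccc(CCl)cc3)c2n1`, gives 53700 nM, and compound 3, `ClCc1ccccc1Cn1cnc2c(Cl)ncnc21`, gives 28200 nM. Compound 1 and compound 3 are built from the same atoms joined differently; the difference between the two cores is not broken down here, and on this read-out the two stand a 5.7-fold higher number from compound 1 to compound 2 (0.75 log units; beyond the scatter) apart only in the sense that compound 3 lies well above compound 1, while compound 3 and compound 2 lie within the usual scatter of each other.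

One change is seen twice among these compounds. From compound 1 to compound 2 it is amino in place of hydrogen on an aromatic carbon, and it made a step of a 5.7-fold higher number from compound 1 to compound 2 (0.75 log units; beyond the scatter).

Compound 4, `Nc1nc(Cl)c2ncn(Cc3ccccc3CCl)c2n1`, has not yet been measured. It differs from compound 3 by amino in place of hydrogen on an aromatic carbon, the same change, at a place described in the same words. Among the compounds with values here, on the strength of the single earlier step of a 5.7-fold higher number from compound 1 to compound 2 (0.75 log units; beyond the scatter), a step of a 4.3-fold higher number from compound 3 to compound 4 (0.63 log units; beyond the scatter) is expected from compound 3 to compound 4 in this assay, with some allowance for the change being seen only once before. Compound 4 is therefore estimated at 120000 nM, with a likely range from 50000 nM to 350000 nM.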

Compound 4, concentration lethal to 50% of the cells: 8510 nM
Beside the measured number, compound 4's estimate is 14-fold (1.15 log units) above it, outside the stated range (below it).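

In this assay, amino in place of hydrogen on an aromatic carbon gave a 3.3-fold lower number from compound 3 to compound 4 (0.52 log units; beyond the scatter), which runs in the opposite direction to the earlier step of a 5.7-fold higher number from compound 1 to compound 2 (0.75 log units; beyond the scatter). The same change therefore did not carry its direction or its size from one core to the other in this series: the same change on two cores in this assay, a 5.7-fold higher number (0.75 log units; beyond the scatter) from compound 1 to compound 2 and a 3.3-fold lower number (0.52 log units; beyond the scatter) from compound 3 to compound 4, 19-fold (1.27 log units) apart, beyond the scatter of two such steps. This shows that the outcome of the change here depends on the core that carries it, but two pairs cannot show which feature of the cores sets the difference, and they give no rule for predicting the step on any further core.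

The compounds shown leave open how other groups would behave in the same place on these two cores, for instance a methylamino group, a dimethylamino group or a hydroxyl group, and whether any of them would split the two cores in the same way as amino does. As far as these compounds go, it also remains open whether the opposite steps would persist if the chloro group on the same ring gave way to a methoxy group or a methyl group.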